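A Hydroxyphenyl Variant of Compound 2

The compounds below may be only part of what the source reports. "The series", "measured", "known", "first", "only" and "open" are said of these compounds alone.

Measured so far:
compound 1 `CC1(C)[C@H]2CC[C@]1(C)N(Cc1cn(-c3cccc(C#N)c3)nn1)C(=O)C2`, 230 nM in a functional assay on OVCAR-3 cells (Homo sapiens) for inhibition, read by MTT assay, with a stated time of 24 h; a lower number here means a stronger inhibitor, a higher number a weaker inhibitor
compound 2 `CC1(C)[C@H]2CC[C@]1(C)N(Cc1cn(-c3ccccc3F)nn1)C(=O)C2`, 300 nM
compound 3 `CC1(C)[C@H]2CC[C@]1(C)N(Cc1cn(-c3ccc(F)cc3)nn1)C(=O)C2`, 200 nM

Compound 2 gives the highest of these three numbers, yet a 1.3-fold higher number from compound 1 to compound 2 (0.12 log units; within the scatter) and a 1.5-fold lower number from compound 2 to compound 3 (0.18 log units; within the scatter) are both within the scatter, so none of the three stands apart.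

Compound 4 `CC1(C)[C@H]2CC[C@]1(C)N(Cc1cn(-c3cccc(O)c3)nn1)C(=O)C2` has not been measured. 3-hydroxyphenyl in place of 2-fluorophenyl on an aromatic nitrogen

Among the measured compounds shown here, two measured steps bear on this change. Replacing 3-cyanophenyl by 2-fluorophenyl gave a 1.3-fold higher number from compound 1 to compound 2 (0.12 log units; within the scatter), and replacing 2-fluorophenyl by 4-fluorophenyl gave a 1.5-fold lower number from compound 2 to compound 3 (0.18 log units; within the scatter). The aryl group on the aromatic nitrogen has thus been varied without any step beyond the scatter. In this assay the expected step is a 1.2-fold lower number from compound 2 to compound 4 (0.08 log units; within the scatter), again within the scatter. Compound 4 is therefore estimated at 250 nM, expected between 110 nM and 560 nM.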

Compound 4, half-maximal inhibitory concentration: 370 nM
Compound 4: middle estimate off by 1.5-fold (0.17 log units), on the low side, and the stated range covers the measured number.
By their numbers in this assay, from the lowest: compounds 3, 1, 2 and 4 (each within the scatter of the next).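

Compound 4 brings a hydrogen-bond donor to the aryl group on the aromatic nitrogen, which the 2-fluorophenyl group it replaces does not have, yet in this assay every new step stays within the scatter: a 1.2-fold higher number from compound 2 to compound 4 (0.09 log units; within the scatter), a 1.9-fold higher number from compound 3 to compound 4 (0.27 log units; within the scatter) and a 1.6-fold higher number from compound 1 to compound 4 (0.21 log units; within the scatter). Among these four compounds, then, adding this donor does not separate compound 4 from the others. Nothing measured here offers an explanation for this.

Going by these compounds, whether an amine or a carboxylic acid on the phenyl ring would give a step beyond the scatter remains open. So does the effect of replacing the phenyl ring with a cyclohexyl group.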